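One inverted stereocentre on a compound at the limit

The source may report more compounds than this note shows. Statements on the series, on what has been measured and on what is new or still open speak of the compounds shown alone.

In an ADME assay on HEK293 cells (Homo sapiens) for cytotoxicity, read by CCK-8 assay, with a stated time of 48 h (a lower number here means a stronger inhibitor, a higher number a weaker inhibitor), compound 1 (`COc1ccc(/C=C\c2cc(OC)c(OC)c(OC)c2)cc1OCc1ccc(CN2CCCC[C@H]2C(=O)O)cc1`) gives > 50000 nM as a limit of the assay. Compound 2 (`COc1ccc(/C=C\c2cc(OC)c(OC)c(OC)c2)cc1OCc1ccc(CNCCO)cc1`) gives > 50000 nM as a limit too. Compound 3 (`COc1ccc(/C=C\c2cc(OC)c(OC)c(OC)c2)cc1OCc1ccc(CN2CC[C@H](C(=O)O)C2)cc1`) gives > 50000 nM as a limit as well, so it has no number of its own. The evidence is the limit of > 50000 nM in this assay, at which 3 of the 3 values shown sit, and nothing finer. Between compound 3 and compound 4 (`COc1ccc(/C=C\c2cc(OC)c(OC)c(OC)c2)cc1OCc1ccc(CN2CC[C@@H](C(=O)O)C2)cc1`) the difference is this: the two compounds have the same atoms and bonds and differ only in configuration as drawn: 1 of 2 stereo elements differ; a stereocentre at a saturated ring carbon is drawn S in compound 3 and R in compound 4 and nothing else. Of the measured steps, a step that the two limits leave unreadable from compound 1 to compound 3 and a step that the two limits leave unreadable from compound 2 to compound 3 touch the group concerned, yet neither has a readable size and neither tests configuration. No step beyond the scatter is therefore expected in this assay for this change. The estimated move is a number no higher from compound 3 to compound 4 (the limit leaves the size open) in either direction. Compound 4 is estimated at 50000 nM with an expected range of 20000 nM to 100000 nM and will most likely be reported as a limit again.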

Compound 4, half-maximal inhibitory concentration: 27000 nM
Beside the measured number, compound 4's estimate is 1.9-fold (0.27 log units) above it; measured number inside the range.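

Going by these compounds alone, compound 4 is the first compound here with a number of its own rather than a limit in this assay: the limit of > 50000 nM in this assay, at which 3 of the 4 values shown sit. The change of configuration gives an at least 1.8-fold lower number from compound 3 to compound 4 (0.26 log units; that floor lies within the scatter), while the other two comparisons give an at least 1.8-fold lower number from compound 2 to compound 4 (0.26 log units; that floor lies within the scatter) and an at least 1.8-fold lower number from compound 1 to compound 4 (0.26 log units; that floor lies within the scatter). All three are floors within the scatter, and the first isolates a single change: the fact that compounds 3 and 4 differ only in the configuration as drawn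

On these data alone, the true size of the configuration step stays open, and the steps among compounds 1, 2 and 3 cannot be read. Also open, as far as these compounds go, is how a primary amide in place of the carboxylic acid of the 3-carboxypyrrolidin-1-yl group would read in this assay.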